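Oxolan-2-yl to oxan-3-yl on the carbonyl carbon

The source may report more compounds than this note shows. Statements on the series, on what has been measured and on what is new or still open speak of the compounds shown alone.

In a functional assay on DU-145 cells (Homo sapiens) for cytotoxicity, read by MTT assay (on this read-out lower numbers stand for stronger inhibition and higher numbers for weaker inhibition), compound 1 (`COCCO[C@H](CC=C(C)C)C1=CC(=O)c2c(O)ccc(O)c2C1=O`) gives 43200 nM, compound 2 (`CC[C@@](C)(O)CC(=O)O[C@H](CC=C(C)C)C1=CC(=O)c2c(O)ccc(O)c2C1=O`) gives 12700 nM and compound 3 (`CC(C)=CC[C@@H](OC(=O)C1CCCO1)C1=CC(=O)c2c(O)ccc(O)c2C1=O`) gives 10500 nM. Compound 3 and compound 2 sit together at the low end of these numbers, as a 1.2-fold lower number from compound 2 to compound 3 (0.08 log units; within the scatter) shows. Compound 4 (`CC(C)=CC[C@@H](OC(=O)C1CCCOC1)C1=CC(=O)c2c(O)ccc(O)c2C1=O`) carries oxan-3-yl in place of oxolan-2-yl on a carbonyl carbon. Among the compounds with values here, the nearest precedent is the group swap on that carbonyl carbon, a 1.2-fold lower number from compound 2 to compound 3 (0.08 log units; within the scatter). The larger 3.4-fold lower number from compound 1 to compound 2 (0.53 log units; beyond the scatter) and a 4.1-fold lower number from compound 1 to compound 3 (0.61 log units; beyond the scatter) are a different kind of change, at the oxygen. No step beyond the scatter is therefore expected in this assay. The expected step is a 1.0-fold higher number from compound 3 to compound 4 (0.02 log units; within the scatter). For compound 4 the estimate is 11000 nM, with an expected range of 5500 nM to 22000 nM.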

Compound 4, half-maximal inhibitory concentration: 29700 nM
Beside the measured number, compound 4's estimate is 2.7-fold (0.43 log units) below it; the measured number lies above the stated range.
By their numbers in this assay, from the lowest: compounds 3 and 2 (each within the scatter of the next); then compounds 4 and 1 (each within the scatter of the next).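

The carbonyl substituent is not a silent position in this assay: oxan-3-yl in place of oxolan-2-yl gives a 2.8-fold higher number from compound 3 to compound 4 (0.45 log units; beyond the scatter), while the earlier swap on this carbon stayed within the scatter. Oxan-3-yl in place of 2-hydroxy-2-methylbutyl gives a 2.3-fold higher number from compound 2 to compound 4 (0.37 log units; beyond the scatter), and the step from 2-methoxyethyl on the oxygen to (oxan-3-yl)carbonyl is only a 1.5-fold lower number from compound 1 to compound 4 (0.16 log units; within the scatter). No available evidence accounts for these steps. The change alters both ring size and attachment point, so the contribution of each remains unresolved. Oxan-2-yl and oxolan-3-yl would separate the two, and an amine on the ring remains open.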